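A few compounds are considered here, and "the series" means these few. Any claim that something is new, unique, unknown or untested is made for them only; others in the source may bear on it.

Three compounds share one core and differ only in their outer groups. Compound 1 `CCCSc1nc(N/N=C/c2ccc(C)cc2)c2nnn(Cc3ccccc3)c2n1`, compound 2 `CCCSc1nc(N/N=C/c2ccccc2Cl)c2nnn(Cc3ccccc3)c2n1` and compound 3 `CCCSc1nc(N/N=C(\C)c2ccccc2O)c2nnn(Cc3ccc(O)cc3)c2n1` were each tested in a functional assay on ECa-109 cells (Homo sapiens) for antiproliferative activity, read by MTT assay, with a stated time of 72 h; on this read-out lower numbers stand for stronger inhibition and higher numbers for weaker inhibition. For compound 1 this assay reports only a limit, > 64000 nM. Compound 2 gives 6180 nM. Compound 3 gives 15900 nM, the higher of the two numbers, with compound 2 the nearest neighbour and clearly beyond the scatter from it. Among the measured compounds shown here, the only measured step between compounds that differ in one place is an at least 10-fold lower number from compound 1 to compound 2 (1.01 log units; beyond the scatter), a change on the ring attached to the carbon with a double bond to nitrogen. Compound 4 `CCCSc1nc(N/N=C(\C)c2ccccc2O)c2nnn(Cc3ccccc3)c2n1` has not been measured. It differs from compound 3 by hydrogen in place of hydroxy on an aromatic carbon. The measured step touches a different ring, so it offers no direct guide, and no step beyond the scatter is expected here. Compound 4 is therefore estimated at 15000 nM, in a range from 6000 nM to 40000 nM, which means an expected step of a 1.1-fold lower number from compound 3 to compound 4 (0.03 log units; within the scatter).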

Compound 4, half-maximal inhibitory concentration: 11100 nM
The estimate for compound 4 lay 1.4-fold (0.13 log units) above the measured number, within the range that was stated.
By their numbers in this assay, from the lowest: compounds 2, 4 and 3 (each within the scatter of the next, the first and the last beyond it). At a limit, above all of these: compound 1.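

Hydrogen in place of hydroxy gives a 1.4-fold lower number from compound 3 to compound 4 (0.16 log units; within the scatter), so at this spot, para to a large group, the 4-hydroxybenzyl and benzyl compounds cannot be told apart in this assay. With benzyl in place, the group on a nitrogen on an aromatic ring can now be compared: the change gives a 1.8-fold higher number from compound 2 to compound 4 (0.25 log units; within the scatter), which leaves these two compounds inseparable as well. Compound 1 is a limit, so an at least 5.7-fold lower number from compound 1 to compound 4 (0.76 log units; beyond the scatter) gives a bound and not a true size: the limit of > 64000 nM in this assay, at which 1 of the 4 values shown sits.

A methoxy group, an amine or a carboxylic acid at the para spot remains open, as hydroxy and hydrogen are the only two groups shown there. Also open, going by these compounds, is how much of the change on the nitrogen comes from the ring hydroxy and how much from the added methyl, as the two always appear together.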